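The source may report more compounds than this note shows. Statements on the series, on what has been measured and on what is new or still open speak of the compounds shown alone.

Compound 3, `CN(C)CCCCn1c2c(c3ccccc31)C(=O)c1c[n+]([O-])c3ccccc3c1C2=O`, gives 310 nM in a functional assay on A549 cells (Homo sapiens) for cytotoxicity, read by MTT assay, with a stated time of 72 h (a lower number here means a stronger inhibitor, a higher number a weaker inhibitor), the lowest of the three numbers measured, though compound 2, `O=C1c2c[n+]([O-])c3ccccc3c2C(=O)c2[nH]c3ccccc3c21`, with 320 nM and compound 1, `CN1CCN(CCCCCCn2c3c(c4ccccc42)C(=O)c2c[n+]([O-])c4ccccc4c2C3=O)CC1`, with 330 nM both stand within the scatter of it. Compound 4, `CN1CCN(CCCn2c3c(c4ccccc42)C(=O)c2c[n+]([O-])c4ccccc4c2C3=O)CC1`, differs from compound 3 in one place: 4-methylpiperazin-1-yl in place of (dimethylamino)methyl on a saturated chain carbon, three bonds along the chain from an aromatic nitrogen. The step of a 1.1-fold lower number from compound 1 to compound 3 (0.03 log units; within the scatter) involves the same two groups on a longer chain, and the step of a 1.0-fold lower number from compound 2 to compound 3 (0.01 log units; within the scatter) shows that adding the whole 4-(dimethylamino)butyl chain also changed nothing beyond the scatter. On that basis no step beyond the scatter is expected in this assay for compound 4, an estimated 1.0-fold higher number from compound 3 to compound 4 (0.01 log units; within the scatter). Compound 4 is therefore expected to give about 320 nM, between 160 nM and 650 nM.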

Compound 4, half-maximal inhibitory concentration: 140 nM
The estimate for compound 4 lay 2.3-fold (0.36 log units) above the measured number; measured number outside the range, below it.
By their numbers in this assay, from the lowest: compound 4; then compounds 3, 2 and 1 (each within the scatter of the next).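

In this assay this chain position proves sensitive to the amine it carries: the step to the 4-methylpiperazin-1-yl group, a 2.2-fold lower number from compound 3 to compound 4 (0.35 log units; beyond the scatter), lies beyond the scatter, as does adding the whole 3-(4-methylpiperazin-1-yl)propyl chain to the aromatic nitrogen, a 2.3-fold lower number from compound 2 to compound 4 (0.36 log units; beyond the scatter). The ring alone does not account for this, since compound 1 carries it on a longer chain and a 2.4-fold lower number from compound 1 to compound 4 (0.37 log units; beyond the scatter) separates the two. Nothing available bears on why these steps arise. As far as these compounds go, whether a morpholine ring or a 4-(4-methylpiperazin-1-yl)butyl chain would match compound 4 remains open.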